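The source may hold more compounds than are shown below. What is called first, only, known or untested is meant among the compounds shown, and "the series" means these compounds.

Going by the values given here, compound 2 `Clc1sccc1-c1cc(-c2cnn(C3CCNCC3)c2)on1` gives the lower of the two numbers so far in an assay on isolated protein for positive allosteric modulation of Neuronal acetylcholine receptor; alpha4/beta2 (Homo sapiens) (a higher number here means that more compound is needed for the effect, a lower number that less compound is needed), at 130 nM, though compound 1 `Fc1ccc(-c2cc(-c3cnn(C4CCNCC4)c3)on2)c(Cl)c1` with 220 nM sits within the scatter of it, as the step of a 1.7-fold lower number from compound 1 to compound 2 (0.23 log units; within the scatter) shows. Compound 3 `Cc1cc(-c2cnn(C3CCNCC3)c2)on1` differs from compound 2 by methyl in place of 2-chlorothiophen-3-yl on an aromatic carbon. Among the compounds with values here, the only measured step swaps one aromatic group for another; no measured step removes such a group in favour of methyl, so nothing bears directly on this change. A rise beyond the scatter is nonetheless expected, with the step of a 12-fold higher number from compound 2 to compound 3 (1.06 log units; beyond the scatter). Compound 3 is estimated at 1500 nM in this assay, between 300 nM and 8000 nM.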

Compound 3, half-maximal effective concentration: 1300 nM
Compound 3: middle estimate off by 1.2-fold (0.06 log units), on the high side; measured number inside the range.
By their numbers in this assay, from the lowest: compounds 2 and 1 (each within the scatter of the next); then compound 3.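

this assay shows a 10-fold higher number from compound 2 to compound 3 (1.00 log units; beyond the scatter) and a 5.9-fold higher number from compound 1 to compound 3 (0.77 log units; beyond the scatter) when methyl takes the place of the aromatic ring group on this carbon next to the ring nitrogen. Going by these compounds alone, the two ring groups had differed only within the scatter, so this is the first change here that goes beyond it, and it holds from either ring group. Nothing available explains the change.

The compounds shown leave open whether a longer chain such as propyl, or a saturated ring such as cyclohexyl, would stay near compound 3 or return towards compound 1 and compound 2.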